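A few compounds are considered here, and "the series" means these few. Any claim that something is new, unique, unknown or untested is made for them only; others in the source may bear on it.

In a functional assay on MDA-MB-231 cells (Homo sapiens) for cytotoxicity, read by sulforhodamine B assay, with a stated time of 72 h (on this read-out higher numbers stand for weaker inhibition of growth and lower numbers for stronger inhibition of growth), compound 3 `CC(=O)/N=C1\NCCC(c2cn(C)c3ccccc23)N1` gives 14400 nM as its growth-inhibition value. Compound 2 `Cn1cc(C2CCN=C(N)N2)c2ccc(Br)cc21` gives 8790 nM in the same test, and these two numbers lie within the usual scatter of each other. Compound 1 `COn1cc(C2CC(=O)N=C(N)N2)c2cc(Br)c(Br)cc21` is reported as "not active" (no number reported) and so offers no number for comparison.

The next structure, compound 4 `CC(=O)/N=C1\NCCC(c2cn(C)c3ccc(Br)cc23)N1`, is compound 3 with bromo in place of hydrogen on an aromatic carbon. Among the measured compounds shown here, no pair of measured compounds shows this change on its own, so the expectation rests on thin evidence. Compound 2 also carries a bromo group and gives 8790 nM without the acetyl group, which hints at a modest gain. Compound 1 carries bromo groups yet was reported without activity, and it goes against any such pattern.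

A modest step is expected, a 3.2-fold lower number from compound 3 to compound 4 (0.51 log units; beyond the scatter) in this assay with the number falling. The estimate for compound 4 is 4500 nM with an expected range from 900 nM to 15000 nM on repeated measurement.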

Compound 4, concentration for 50% growth inhibition: 940 nM
Estimate against measurement, compound 4: 4.8-fold (0.68 log units) above; measured number inside the range.
By their numbers in this assay, from the lowest: compound 4; then compounds 2 and 3 (each within the scatter of the next).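

In this assay, bromo in place of hydrogen on an aromatic carbon of the six-membered aromatic ring brings a 15-fold lower number from compound 3 to compound 4 (1.19 log units; beyond the scatter) and so stands as a large step. Among the compounds shown here, this pair is the first in the set to isolate this change, and it shows that growth inhibition responds strongly to what sits at this one carbon, with the rest of the structure held the same. Nothing measured here explains why this exchange has so large an effect.

On these data alone, it remains open whether other groups at this carbon, such as chloro, methoxy or an amine, would give a similar step. As far as these compounds go, it is also open whether the same exchange would matter as much in a compound without the acetyl group, such as compound 2.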